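The source may report more compounds than this note shows. Statements on the series, on what has been measured and on what is new or still open speak of the compounds shown alone.

Measured so far:
compound 1 `COc1cc(-c2nn(-c3cccc(NC(=O)c4cccc(C(F)(F)F)c4)c3)cc2-c2ccncc2)ccc1Cl` — 895 nM
compound 2 `O=C(Nc1cccc(-n2cc(-c3ccncc3)c(-c3ccc(Cl)c(O)c3)n2)c1)Nc1ccc(Cl)c(C(F)(F)F)c1` — 782 nM

In a functional assay on SF-539 cells (Homo sapiens) for inhibition, read by sulforhodamine B assay, with a stated time of 48 h (a higher number here means a weaker inhibitor of growth, a lower number a stronger inhibitor of growth), compound 1 gives 895 nM, the higher of the two numbers, but compound 2 gives 782 nM, which lies within the usual scatter, so the two cannot be ranked. Compound 3 `COc1cc(-c2nn(-c3cccc(NC(=O)Nc4ccc(Cl)c(Cl)c4)c3)cc2-c2ccncc2)ccc1Cl` is not yet measured. It differs from compound 1 in one place: (3,4-dichlorophenyl)amino in place of 3-(trifluoromethyl)phenyl on a carbonyl carbon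

Compound 2 already varies this same region of the molecule without moving the number, as its value 782 nM shows. The step in this assay is therefore expected to be small, a 1.2-fold lower number from compound 1 to compound 3 (0.08 log units; within the scatter), none beyond the scatter. Compound 3 is expected to give about 750 nM, between 300 nM and 1900 nM.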

Compound 3, concentration for 50% growth inhibition: 965 nM
Compound 3: the middle estimate sits 1.3-fold (0.11 log units) below what was measured; measured number inside the range.
By their numbers in this assay, from the lowest: compounds 2, 1 and 3 (each within the scatter of the next).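

In this assay, placing (3,4-dichlorophenyl)amino on the carbonyl carbon instead of 3-(trifluoromethyl)phenyl gives a 1.1-fold higher number from compound 1 to compound 3 (0.03 log units; within the scatter), so compound 1 and compound 3 cannot be told apart. This single-place comparison shows that the number holds when a hydrogen-bond donor and two chlorines enter and the trifluoromethyl group leaves. No measurement here offers an explanation for this. Still open, as far as these compounds go, is how the number would respond if a carboxylic acid or a simple alkyl amine, neither carrying an aromatic ring, stood on this carbonyl carbon.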